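Adding a Methyl to a Potent Oxime Ether Alkyne

The compounds below may be only part of what the source reports. "The series", "measured", "known", "first", "only" and "open" are said of these compounds alone.

The set holds two measured compounds and one awaiting measurement. Compound 1 `Cc1cccc(C#CC2=C/C(=N/Oc3cccc(F)n3)CCC2)n1` gives 46.8 nM in an assay on brain (strain Sprague-Dawley) for displacement of a labelled ligand from metabotropic glutamate receptor 5 (Rattus norvegicus), with a stated time of 45 min; on this read-out lower numbers stand for stronger inhibition and higher numbers for weaker inhibition. Compound 2 `FCCOCCO/N=C1/C=C(C#Cc2ccccn2)CCC1` gives 3.8 nM in this assay, the lowest of the two numbers shown; compound 1 stands well higher, and the gap between the two lies beyond the scatter. Since these two compounds differ in more than one place, their values show which is the stronger binder, not which part of the structure accounts for the gap.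

Compound 3 `Cc1cccc(C#CC2=C/C(=N/OCCOCCF)CCC2)n1` is compound 2 with a single change: methyl in place of hydrogen on an aromatic carbon, which reads as pyridin-2-yl becoming 6-methylpyridin-2-yl. Among the measured compounds shown here, no measured pair isolates this change. With the rest of compound 2 kept intact, a methyl on an aromatic carbon is a small addition. Compound 3 is expected to show a step of a 1.3-fold lower number from compound 2 to compound 3 (0.10 log units; within the scatter), near zero or a small gain and not clearly beyond the scatter. The estimate for compound 3 in this assay is 3 nM, with a range from 1 nM to 12 nM.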

Compound 3, inhibition constant in the metabotropic glutamate receptor 5 assay: 26.8 nM
Compound 3: the middle estimate sits 8.9-fold (0.95 log units) below what was measured; the whole stated range lies below it.
By their numbers in the metabotropic glutamate receptor 5 assay, from the lowest: compound 2; then compounds 3 and 1 (each within the scatter of the next).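

On the pyridin-2-yl compound, methyl in place of hydrogen next to the ring nitrogen proves to matter in the metabotropic glutamate receptor 5 assay, with the change giving a 7.1-fold higher number from compound 2 to compound 3 (0.85 log units; beyond the scatter). With 6-methylpyridin-2-yl held constant, the exchange on the oxygen reads in the metabotropic glutamate receptor 5 assay as a 1.7-fold lower number from compound 1 to compound 3 (0.24 log units; within the scatter), so 2-(2-fluoroethoxy)ethyl and 6-fluoropyridin-2-yl cannot be separated on this pair. In a physicochemical assay for lipophilicity, using the shake flask method, with a stated time of 15 min (a higher number here means a more lipophilic compound, a lower number a more polar compound), compound 2 gives 1.7 and compound 3 gives 2.1. The methyl also makes the compound more lipophilic in the physicochemical assay, a shift that accompanies the weaker binding without being shown to account for it: the measured distribution coefficient of compound 2, 1.7, and of compound 3, 2.1, a number 0.40 log units higher (beyond the scatter)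

From the compounds shown here alone, whether the loss is particular to methyl, or would also follow an ethyl, a chlorine or a methoxy group at the same place, stays open. Going by these compounds, the effect of the methyl rests on a single pair, so it also remains unknown whether it would carry over to other groups on the oxygen, such as 6-fluoropyridin-2-yl or a longer ether chain.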